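The source may report more compounds than this note shows. Statements on the series, on what has been measured and on what is new or still open speak of the compounds shown alone.

Going by the values given here, compound 1, `Nc1ncccc1-c1nc2cccnc2n1-c1ccc(CNC(=O)C2CCCCC2)cc1`, is the only compound of the pair that gives a number in an in vitro assay on Sf9 cells for inhibition of RAC-alpha serine/threonine-protein kinase (Homo sapiens), read by AlphaScreen, with a stated time of 20 min; on this read-out higher numbers stand for weaker inhibition and lower numbers for stronger inhibition: compound 1 reaches 250 nM. Compound 2, `CC(C)(C)c1ccc(-n2c(-c3cccnc3N)nc3cc(Br)cnc32)cc1`, is shown beside it but returns only a limit of the assay; in this assay compound 2 gives > 300000 nM. That leaves compound 1 as the single measured anchor, with one limit alongside it, (the limit of > 300000 nM in this assay, at which 1 of the 2 values shown sits).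

Compound 3, `Nc1ccc(-n2c(-c3cccnc3N)nc3cccnc32)cc1`, differs from compound 1 in a single place: amino in place of ((cyclohexylcarbonyl)amino)methyl on an aromatic carbon. The group that leaves is a large one, and what enters is a single nitrogen on an aromatic carbon, para to a large group.

Among the compounds with values here, no measured pair shows what this exchange does, so the expectation rests on the size of the change alone. The author expects compound 3 to be weaker than compound 1, by the step of a 10-fold higher number from compound 1 to compound 3 (1.00 log units; beyond the scatter), which lies beyond the usual scatter. Compound 3 is therefore estimated at 2500 nM in this assay, within a range from 500 nM to 15000 nM.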

Compound 3, half-maximal inhibitory concentration: 740 nM
For compound 3 the middle estimate is 3.4-fold (0.53 log units) above the measured one, within the range that was stated.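

In this assay, putting amino in place of ((cyclohexylcarbonyl)amino)methyl on this aromatic carbon gives a 3.0-fold higher number from compound 1 to compound 3 (0.47 log units; beyond the scatter), a modest loss of inhibition. Going by these compounds alone, this is the first measured look at this position, and it shows that the cyclohexane ring and the carbonyl are not needed for a measurable value: with only amino left there, compound 3 still gives 740 nM in this read-out. Nothing measured here bears on why the exchange costs this much.

The compounds shown leave open which part of the large group accounts for the step. An aminomethyl group, an acetamidomethyl group or a carboxylic acid on this carbon could show whether the carbonyl, the cyclohexane ring or the chain length matters most.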